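Cytotoxicity notes: 2-fluorophenyl to 4-chlorophenyl

The source may report more compounds than this note shows. Statements on the series, on what has been measured and on what is new or still open speak of the compounds shown alone.

Three compounds sharing one core have readings so far in an ADME assay on BJ cells (Homo sapiens) for cytotoxicity, with a stated time of 72 h (on this read-out higher numbers stand for an effect only at larger amounts of compound and lower numbers for an effect already at smaller amounts), on record. Compound 1 (`Cc1cc(NC(=O)Nc2ccc(Cl)c(Cl)c2)c2ccccc2n1`) gives 23000 nM as a plain number. Compound 2 (`Cc1cc(NC(=O)Nc2ccc(C(=O)O)cc2)c2ccccc2n1`) gives > 25000 nM as a limit of the assay. Compound 3 (`Cc1cc(NC(=O)Nc2ccccc2F)c2ccccc2n1`) gives > 25000 nM as a limit too. Compound 3 therefore stands at the limit of > 25000 nM in this assay, at which 2 of the 3 values shown sit, and has no number of its own. Compound 4 (`Cc1cc(NC(=O)Nc2ccc(Cl)cc2)c2ccccc2n1`) has 4-chlorophenyl in place of 2-fluorophenyl on an amide-type nitrogen. Within the data shown here, no measured step of a single change is available. With compound 1 at 23000 nM, no step beyond the scatter is expected in this assay for this change. The estimated move (a number no higher from compound 3 to compound 4 (the limit leaves the size open)) is expected to stay within the scatter. Compound 4 is estimated at 25000 nM (range 14000 nM to 40000 nM).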

Compound 4, half-maximal effective concentration: > 25000 nM
Compound 4 gave a limit, no number; the forecaster's own chance of this, stated with the estimate: 60%; the middle value lies on the limit itself.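

In this assay, the steps to compound 4 from compound 3 and from compound 2 cannot be read, since both ends of each are limits. Among these compounds, the one readable step, hydrogen in place of chloro on an aromatic carbon, gives an at least 1.0-fold higher number from compound 1 to compound 4 (0.03 log units; that floor lies within the scatter). With compound 4, the 4-chlorophenyl group joins the 2-fluorophenyl group at the limit: the limit of > 25000 nM in this assay, at which 3 of the 4 values shown sit.

Going by these compounds, only compound 1 has a plain number, so the distance of the other compounds from the limit stays open. On these data alone, whether an amine or a longer chain in place of 4-chlorophenyl on the amide-type nitrogen would give a plain number also stays open.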